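The source may hold more compounds than are shown below. What is called first, only, known or untested is meant among the compounds shown, and "the series" means these compounds.

Working notes on the series. Compound 1 `COc1ccc(NS(=O)(=O)c2cc3cccc(Br)c3oc2=O)cc1` gives 18000 nM in a functional assay on NCI-H157 cells (Homo sapiens), with a stated time of 96 h; on this read-out lower numbers stand for stronger inhibition of growth and higher numbers for weaker inhibition of growth; compound 2 `COc1ccc(NS(=O)(=O)c2cc3cc(Cl)ccc3oc2=O)cc1` gives 28000 nM; compound 3 `CCOc1cccc2cc(S(=O)(=O)Nc3ccc(OC)cc3)c(=O)oc12` gives 74000 nM, the highest of the three numbers, beyond the scatter from each of the others. Going by the values given here, the one single-site step among them, a 4.1-fold higher number from compound 1 to compound 3 (0.61 log units; beyond the scatter), concerns a substituent on the shared core and not the group changed here.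

Compound 4 `CCOc1cccc2cc(S(=O)(=O)Nc3ccc(Br)cc3)c(=O)oc12` differs from compound 3 by bromo in place of methoxy on an aromatic carbon, on an aromatic carbon of a six-membered aromatic ring of carbon only, para to a large group. Among the compounds with values here, no measured pair varies this position, so the measured step gives no direct guidance; the closest analogy is only that an exchange of a halogen for an alkoxy group elsewhere on the core moved the number within a modest range. The expected step for compound 4 is therefore no change at the digits printed from compound 3 to compound 4 (within the scatter), meaning no change clearly beyond the scatter is anticipated in either direction. The estimate for compound 4 is 74000 nM, with a range from 25000 nM to 220000 nM.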

Compound 4, concentration for 50% growth inhibition: 74000 nM
Estimate against measurement, compound 4: no gap at the digits printed; measured number inside the range.
By their numbers in this assay, from the lowest: compounds 1 and 2 (each within the scatter of the next); then compounds 3 and 4 (each within the scatter of the next).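

In this assay, going by these compounds alone, bromo in place of methoxy gives no change at the digits printed from compound 3 to compound 4 (within the scatter), the only measured step at this position, whereas the earlier step concerned a substituent on the shared core. With ethoxy held constant on the core, the change from 4-methoxyphenyl to 4-bromophenyl, which swaps two heavy atoms and one hydrogen-bond acceptor for one heavy atom and no acceptor, leaves the read-out within the scatter. No available measurement bears on why these two groups read alike.

As far as these compounds go, it remains open whether the same exchange would also leave the number unmoved with bromo on the core, as in compound 1, rather than ethoxy. Also open, from the compounds shown here alone, is whether an amine, a carboxylic acid or a longer alkoxy chain at this place would shift the number beyond the scatter.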